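The source may report more compounds than this note shows. Statements on the series, on what has been measured and on what is new or still open speak of the compounds shown alone.

Measured in a functional assay on MCF7 cells (Homo sapiens) for cytotoxicity; a lower number here means a stronger inhibitor, a higher number a weaker inhibitor:
compound 1 `N#C/N=C1\N(CCCCCOc2ccc(Cl)cc2)C(=O)CN1c1ccncc1` gives 5360 nM
compound 2 `N#C/N=C1\N(CCCCCCOc2ccc(Cl)cc2)C(=O)CN1c1ccncc1` gives 443 nM
compound 3 `N#C/N=C1\N(CCCCCOc2ccc(Cl)cc2)C(=O)CCN1c1ccncc1` gives 5460 nM

Compounds 1 and 2 share one core; compound 3 carries a different core, and the difference between the two cores is not broken down here. Compound 1 and compound 3 lie within the scatter of each other in this assay, so nothing separates them. Going by the values given here, the one counted change in the set is (4-chlorophenoxy)methyl in place of 4-chlorophenoxy on a saturated chain carbon, five bonds along the chain from an amide-type nitrogen in a ring, and it produced a 12-fold lower number from compound 1 to compound 2 (1.08 log units; beyond the scatter). Among the compounds with values here, compound 4 `N#C/N=C1\N(CCCCCCOc2ccc(Cl)cc2)C(=O)CCN1c1ccncc1` is not yet measured; it differs from compound 3 by (4-chlorophenoxy)methyl in place of 4-chlorophenoxy on a saturated chain carbon, five bonds along the chain from an amide-type nitrogen in a ring, the same change as the one from compound 1 to compound 2, made at the same place on the other core.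

Within the data shown here, with a single precedent and no measured pair showing how the two cores respond to the same change, the expectation for compound 4 rests on the step from compound 1 to compound 2 alone, given as a 12-fold lower number from compound 1 to compound 2 (1.08 log units; beyond the scatter), and is therefore held a little short of it: the estimated step for compound 4 is an 8.4-fold lower number from compound 3 to compound 4 (0.92 log units; beyond the scatter). On that basis compound 4 is expected to give about 650 nM in this assay, estimated between 220 nM and 2200 nM.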

Compound 4, half-maximal inhibitory concentration: 454 nM
For compound 4 the middle estimate is 1.4-fold (0.16 log units) above the measured one, within the range that was stated.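

In this assay, (4-chlorophenoxy)methyl in place of 4-chlorophenoxy on a saturated chain carbon, five bonds along the chain from an amide-type nitrogen in a ring, gives a 12-fold lower number from compound 3 to compound 4 (1.08 log units; beyond the scatter), so the change is also large on the core of compound 3. Going by these compounds alone, the comparison covers only this one change on two cores in one cell assay, so it shows neither why the step holds nor whether other changes, or this change on further cores, would carry over in the same way. For this pair of cores, the size of the step carries over with no difference that can be told apart: the same change on two cores in this assay, a 12-fold lower number (1.08 log units; beyond the scatter) from compound 1 to compound 2 and a 12-fold lower number (1.08 log units; beyond the scatter) from compound 3 to compound 4, 1.0-fold (0.00 log units) apart, within the scatter of two such steps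

From the compounds shown here alone, whether the trend continues with 2-(4-chlorophenoxy)ethyl or a longer chain at the same place remains open on both cores. Also open, going by these compounds, is how either core responds when an amine or a carboxylic acid takes the place of the 4-chlorophenoxy group at the chain end.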